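Series notes: carbamoyl for methoxy at the imidazole carbon

This account rests on a few compounds, and the source may have more. Where it says the series, first, only, none or still open, it means among the compounds named here.

Compound 3 `CCc1nc(OC)c2n1CCN([C@@H](C(=O)NC)c1ccccc1)C2CCc1ccc(C(F)(F)F)cc1` gives 73 nM in a functional assay on CHO cells for antagonist activity at Orexin receptor type 2 (Homo sapiens), read by FLIPR and calcium flux; on this read-out lower numbers stand for stronger inhibition and higher numbers for weaker inhibition. Among the three measured compounds it stands second highest: compound 2 `C=Cc1nc(CC)n2c1C(CCc1ccc(C(F)(F)F)cc1)N([C@@H](C(=O)NC)c1ccccc1)CC2` gives 23 nM, and compound 1 `CCc1nc(C(C)C)c2n1CCN([C@@H](C(=O)NC)c1ccccc1)C2CCc1ccc(C(F)(F)F)cc1` gives 2900 nM. The steps at this aromatic carbon are large: a 130-fold lower number from compound 1 to compound 2 (2.10 log units; beyond the scatter), a 40-fold lower number from compound 1 to compound 3 (1.60 log units; beyond the scatter), while a 3.2-fold higher number from compound 2 to compound 3 (0.50 log units; beyond the scatter). Every substitution at this carbon measured so far has moved the number well beyond the scatter, with the isopropyl of compound 1 giving by far the highest value.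

Compound 4 `CCc1nc(C(=O)N(C)C)c2n1CCN([C@@H](C(=O)NC)c1ccccc1)C2CCc1ccc(C(F)(F)F)cc1` differs from compound 3 by dimethylcarbamoyl in place of methoxy on an aromatic carbon. Going by the values given here, no measured pair carries exactly this change, so the expectation rests on the spread at this position. The entering group is the largest yet placed there, and compound 1 shows that a bulkier group gave 2900 nM. A higher number is therefore expected for compound 4, of uncertain size: the step of an 8.2-fold higher number from compound 3 to compound 4 (0.91 log units; beyond the scatter) is estimated. Compound 4 is expected to give 600 nM in this assay, within 100 nM to 4000 nM.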

Compound 4, half-maximal inhibitory concentration: 111 nM
Compound 4: the middle estimate sits 5.4-fold (0.73 log units) above what was measured; the measured number falls inside the stated range.
By their numbers in this assay, from the lowest: compound 2; then compounds 3 and 4 (each within the scatter of the next); then compound 1.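

In this assay, replacing methoxy with dimethylcarbamoyl, which has more heavy atoms, does not separate the two compounds: a 1.5-fold higher number from compound 3 to compound 4 (0.18 log units; within the scatter). Heavy-atom count therefore does not order the numbers at this aromatic carbon, as dimethylcarbamoyl gives a 26-fold lower number from compound 1 to compound 4 (1.42 log units; beyond the scatter), although isopropyl is the smaller group, while the step from the vinyl compound is a 4.8-fold higher number from compound 2 to compound 4 (0.68 log units; beyond the scatter). Nothing measured here accounts for why isopropyl stands apart from the other three groups.

Still open, on these data alone, is whether a primary carbamoyl or a carboxylic acid at this carbon would stay in the range of compound 3 and compound 4. Also open, as far as these compounds go, is whether a tert-butyl or cyclopropyl group would follow isopropyl or vinyl.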